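This account rests on a few compounds, and the source may have more. Where it says the series, first, only, none or still open, it means among the compounds named here.

Working notes on the series. Among the measured compounds shown here, compound 1 `Cc1c2c(n3c1CCNC[C@@H](C)[C@H](C)Nc1cc-3ccc1C(N)=O)CC(C)(C)CC2=O` gives 40 nM in a functional assay on U-87MG ATCC cells (Homo sapiens) for antiproliferative activity (on this read-out higher numbers stand for weaker inhibition and lower numbers for stronger inhibition), the lowest of the two numbers measured so far. Compound 2 `Cc1c2c(n3c1CCCN(C)[C@@H](C)[C@H](C)Nc1cc-3ccc1C(N)=O)CC(C)(C)CC2=O` gives 133 nM in this assay, a higher number, beyond the scatter. Compound 3 `Cc1c2c(n3c1CCN(C(=O)C1(N)CCCC1)C[C@@H](C)[C@H](C)Nc1cc-3ccc1C(N)=O)CC(C)(C)CC2=O` is yet to be measured; it differs from compound 1 by a group of 8 heavy atoms (6 carbon, 1 nitrogen, 1 oxygen; one five-membered non-aromatic ring of carbon only) in place of a hydrogen atom, on an amine nitrogen in a ring. For the measured compounds named here, no measured pair shows a change of this kind, so the expectation rests only on the two numbers above. For compound 3 a step of a 2.5-fold higher number from compound 1 to compound 3 (0.40 log units; beyond the scatter) toward a higher number is expected. Compound 3 is estimated at 100 nM, within a range of 30 nM to 350 nM.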

Compound 3, half-maximal inhibitory concentration: 44 nM
Compound 3: middle estimate off by 2.3-fold (0.36 log units), on the high side; the range from low to high includes it.
By their numbers in this assay, from the lowest: compounds 1 and 3 (each within the scatter of the next); then compound 2.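

In this assay, the hydrogen atom on this amine nitrogen in a ring gives way to a group of 8 heavy atoms, with one five-membered non-aromatic ring of carbon only, and the step is a 1.1-fold higher number from compound 1 to compound 3 (0.04 log units; within the scatter), which shows that this position takes the group with no change beyond the scatter. No measurement on hand accounts for this result. Still open, as far as these compounds go, is whether an acetyl group at this nitrogen, or a carboxylic acid in place of the amine of the entering group, would hold the number.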